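From a Free Acid to a tert-Butyl Amide

The compounds below may be only part of what the source reports. "The series", "measured", "known", "first", "only" and "open" are said of these compounds alone.

The measured compounds, in a functional assay for inhibition of nuclear factor NF-kappa-B complex (Homo sapiens); on this read-out lower numbers stand for stronger inhibition and higher numbers for weaker inhibition:
Compound 1 `COc1ccc2c(c1)OC(c1cc(OC)c(OC)c(OC)c1)C(C(=O)OC(C)(C)C)=C2` gives 14100 nM.
Compound 2 `COc1ccc2c(c1)OC(c1cc(OC)c(OC)c(OC)c1)C(C(=O)O)=C2` gives only a limit, > 50000 nM.
Compound 3 `COc1ccc2c(c1)OC(c1cc(OC)c(OC)c(OC)c1)C(C(=O)Nc1ccccc1)=C2` gives 17500 nM.

Compound 2 stands apart from the other two: its value is a limit of this assay, not a number (the limit of > 50000 nM in this assay, at which 1 of the 3 values shown sits), and both of its measured neighbours lie beyond the scatter from it. The unmeasured compound 4 `COc1ccc2c(c1)OC(c1cc(OC)c(OC)c(OC)c1)C(C(=O)NC(C)(C)C)=C2` differs from compound 2 in one place: (tert-butyl)amino in place of hydroxy on a carbonyl carbon.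

For the measured compounds named here, two measured steps bear on this change. The step of an at least 2.8-fold lower number from compound 2 to compound 3 (0.45 log units; beyond the scatter) shows that replacing the hydroxy on the carbonyl carbon with an amine-linked group brings the value from the limit down to a measurable number. The step of an at least 3.5-fold higher number from compound 1 to compound 2 (0.54 log units; beyond the scatter) shows the reverse direction, a capped carbonyl becoming a free acid, with the number rising to the limit. The step of a 1.2-fold higher number from compound 1 to compound 3 (0.09 log units; within the scatter) shows that the tert-butoxy and anilino caps sit within the scatter of each other. A tert-butyl cap on nitrogen is therefore expected to behave like these caps, and compound 4 is expected to show a step of an at least 3.3-fold lower number from compound 2 to compound 4 (0.52 log units; beyond the scatter) in this assay. Compound 4 is estimated at 15000 nM, with a range from 6000 nM to 40000 nM.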

Compound 4, half-maximal inhibitory concentration: 28400 nM
Beside the measured number, compound 4's estimate is 1.9-fold (0.28 log units) below it; the range from low to high includes it.
By their numbers in this assay, from the lowest: compounds 1, 3 and 4 (each within the scatter of the next). At a limit, above all of these: compound 2.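

In this assay, the change from hydroxy to (tert-butyl)amino on the carbonyl carbon gives an at least 1.7-fold lower number from compound 2 to compound 4 (0.24 log units; that floor lies within the scatter), so unlike the anilino and tert-butoxy caps, this cap cannot be read as clearly separated from the free acid. Compound 2 remains a limit of the assay and not a number, which leaves the true size of this step unknown: the limit of > 50000 nM in this assay, at which 1 of the 4 values shown sits.

Among the capped compounds, a 1.6-fold higher number from compound 3 to compound 4 (0.21 log units; within the scatter) and a 2.0-fold higher number from compound 1 to compound 4 (0.30 log units; within the scatter) both lie within the scatter, so tert-butyl and phenyl on the amide-type nitrogen are not told apart here, and neither are (tert-butyl)amino and tert-butoxy on the carbonyl carbon.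

The compounds shown leave open whether a smaller cap on this carbonyl carbon, such as methylamino, methoxy or a plain unsubstituted amino group, would also give a measurable number in this assay. They also leave open whether a longer chain ending in an amine, or an anilino group carrying a substituent on its phenyl, could reach a number beyond the scatter from those of compounds 1, 3 and 4.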